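The compounds below may be only part of what the source reports. "The series", "measured", "known", "first", "only" and "open" are said of these compounds alone.

Compound 1 `CN1CCN(CCCCCCn2c3c(c4ccccc42)C(=O)c2c[n+]([O-])c4ccccc4c2C3=O)CC1` gives 5800 nM in a toxicity assay on HEK-293T cells (Homo sapiens) for cytotoxicity, read by MTT assay, with a stated time of 72 h; on this read-out higher numbers stand for weaker inhibition and lower numbers for stronger inhibition. Compound 2 `O=C1c2c[n+]([O-])c3ccccc3c2C(=O)c2c1c1ccccc1n2Cc1cn([C@H]2C[C@H](O)[C@@H](CO)O2)nn1` gives 3600 nM. Compound 3 `CC1(C)O[C@@H](CO)[C@H](Cn2cc(Cn3c4c(c5ccccc53)C(=O)c3c[n+]([O-])c5ccccc5c3C4=O)nn2)O1` gives 120 nM.

Among these three, compound 3 stands with the lowest number; compound 2 and compound 1 both stand well beyond the scatter above it. Compound 4 `O=C1c2c[n+]([O-])c3ccccc3c2C(=O)c2c1c1ccccc1n2Cc1cn(C[C@H](O)CO)nn1` differs from compound 3 in this way: 1,2-dihydroxyethyl in place of 5-(hydroxymethyl)-2,2-dimethyl-1,3-dioxolan-4-yl on a saturated chain carbon bound to an aromatic nitrogen. For the measured compounds named here, the one measured step that bears on the same kind of position is a 30-fold lower number from compound 2 to compound 3 (1.48 log units; beyond the scatter), where the acetonide-bearing group entered in place of a more hydroxyl-rich cyclic group. Compound 4 reverses part of that direction, so the account expects the number for compound 4 to move upward, toward compound 2, by a 13-fold higher number from compound 3 to compound 4 (1.10 log units; beyond the scatter). Compound 4 is therefore estimated at 1500 nM, with a range from 400 nM to 6000 nM.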

Compound 4, half-maximal inhibitory concentration: 8880 nM
Compound 4: the middle estimate sits 5.9-fold (0.77 log units) below what was measured, outside the stated range (above it).
By their numbers in this assay, from the lowest: compound 3; then compounds 2, 1 and 4 (each within the scatter of the next, the first and the last beyond it).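

Among the compounds shown, the low number of compound 3 depends on keeping the 5-(hydroxymethyl)-2,2-dimethyl-1,3-dioxolan-4-yl group: in this assay, 1,2-dihydroxyethyl in its place gives the largest step so far (a 74-fold higher number from compound 3 to compound 4 (1.87 log units; beyond the scatter)). The open-chain 2,3-dihydroxypropyl group also stands modestly above the cyclic group of compound 2 (a 2.5-fold higher number from compound 2 to compound 4 (0.39 log units; beyond the scatter)). Compound 4 cannot be separated from compound 1, which carries 5-(4-methylpiperazin-1-yl)pentyl (a 1.5-fold higher number from compound 1 to compound 4 (0.18 log units; within the scatter)).

From the compounds shown here alone, what a primary amine or a carboxylic acid would give at this chain carbon remains open. Nothing available explains why the change has so large an effect.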